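Phenyl substituent changes on the shared core

The compounds below may be only part of what the source reports. "The series", "measured", "known", "first", "only" and "open" are said of these compounds alone.

Among the measured compounds shown here, compound 1 `C/C(=C\CC/C(C)=C/CC[C@@H]1[C@@]2(C)CCC(=O)C(C)(C)[C@H]2CC[C@@]1(C)O)CC/C=C(\C)C(=O)OCc1cn(-c2cccc(C)c2)nn1` is the only member with an actual number in a functional assay on DU-145 cells (Homo sapiens) for antiproliferative activity, read by MTT assay, with a stated time of 48 h (a higher number here means a weaker inhibitor, a lower number a stronger inhibitor), where compound 1 gives 137000 nM. Compound 2 `C/C(=C\CC/C(C)=C/CC[C@@H]1[C@@]2(C)CCC(=O)C(C)(C)[C@H]2CC[C@@]1(C)O)CC/C=C(\C)C(=O)OCc1cn(-c2cccc(Br)c2)nn1` reaches only a limit of the assay in this assay, namely > 150000 nM. Compound 3 `C/C(=C\CC/C(C)=C/CC[C@@H]1[C@@]2(C)CCC(=O)C(C)(C)[C@H]2CC[C@@]1(C)O)CC/C=C(\C)C(=O)OCc1cn(-c2ccc(C)cc2)nn1` likewise gives only a limit in this assay, > 150000 nM. The steps of an at least 1.0-fold higher number from compound 1 to compound 2 (0.03 log units; that floor lies within the scatter) and an at least 1.0-fold higher number from compound 1 to compound 3 (0.03 log units; that floor lies within the scatter) both end at the limit of > 150000 nM in this assay, at which 2 of the 3 values shown sit. Compound 4 `C/C(=C\CC/C(C)=C/CC[C@@H]1[C@@]2(C)CCC(=O)C(C)(C)[C@H]2CC[C@@]1(C)O)CC/C=C(\C)C(=O)OCc1cn(-c2cccc(O)c2)nn1` carries the change (hydroxy in place of methyl on an aromatic carbon). Neither measured step involves a hydroxy group, and both fix only a floor that sits within the scatter; the expectation for compound 4 in this assay is therefore a step of a 1.1-fold higher number from compound 1 to compound 4 (0.04 log units; within the scatter), landing at or around the limit. Compound 4 is estimated at 150000 nM, within 80000 nM to 300000 nM.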

Compound 4, half-maximal inhibitory concentration: 28400 nM
Estimate against measurement, compound 4: 5.3-fold (0.72 log units) above; measured number below the stated range.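

In this assay, among the compounds shown here, hydroxy in place of methyl gives a 4.8-fold lower number from compound 1 to compound 4 (0.68 log units; beyond the scatter), the first step that is readable beyond the scatter. The change also stands out against the other two compounds, with hydroxy in place of bromo giving an at least 5.2-fold lower number from compound 2 to compound 4 (0.72 log units; beyond the scatter) and 3-hydroxyphenyl in place of 4-methylphenyl giving an at least 5.2-fold lower number from compound 3 to compound 4 (0.72 log units; beyond the scatter). These two steps are floors only, as each starts from a limit of the assay: the limit of > 150000 nM in this assay, at which 2 of the 4 values shown sit.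

From the compounds shown here alone, whether an amine or a methoxy group in place of hydroxy gives a step of similar size stays open.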